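The compounds below may be only part of what the source reports. "The series", "measured", "known", "first", "only" and "open" are said of these compounds alone.

Measured compounds:

Compound 1, `O=C(/C=C/c1ccccc1)c1ccc(N2CCN(c3ccc(Cl)c(Cl)c3)CC2)cc1`: in a functional assay on the whole organism (strain Kunming) for inhibition, with Mus musculus as the target, with a stated time of 1 h, at a dose of 40 mg/kg by the oral route (on this read-out lower numbers stand for less inhibition and higher numbers for more inhibition at the one dose given (going by the name of the read-out)), compound 1 gives 13.4%.
Compound 2, `Cc1ccc(N2CCN(c3ccc(C(=O)/C=C/c4ccccc4)cc3)CC2)c(C)c1`: compound 2 gives 15%.
Compound 3, `COc1ccc(/C=C/C(=O)c2ccc(N3CCN(c4ccc(Cl)c(Cl)c4)CC3)cc2)cc1OC`: compound 3 gives 63.5%.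

Compound 3 stands highest of the three. Its nearest neighbour is compound 2, and the gap between them is beyond the scatter; compound 1 lies furthest, and the step of a number 50.1 percentage points higher from compound 1 to compound 3 (beyond the scatter) is large and beyond the scatter. The step of a number 1.6 percentage points higher from compound 1 to compound 2 (within the scatter), by contrast, is within the scatter.

Compound 4, `COc1ccc(/C=C/C(=O)c2ccc(N3CCN(c4ccc(C)cc4C)CC3)cc2)cc1OC`, differs from compound 3 in one place: 2,4-dimethylphenyl in place of 3,4-dichlorophenyl on an amine nitrogen in a ring. The same exchange has already been made once, from compound 1 to compound 2, where it gave a number 1.6 percentage points higher from compound 1 to compound 2 (within the scatter), a change too small to count. That single step is the only one bearing on the present change, so the step of a number 0.5 percentage points lower from compound 3 to compound 4 (within the scatter) is expected to stay within the scatter, with no clear direction. Compound 4 is therefore estimated at 63%, most likely between 45% and 80%.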

Compound 4, a percentage reported as inhibition, in the whole organism at one dose (the size of the read-out at that dose, not a potency): 48.5%
For compound 4 the middle estimate is 14.5 percentage points above the measured one; the measured number falls inside the stated range.
By their numbers in this assay, from the lowest: compounds 1 and 2 (each within the scatter of the next); then compound 4; then compound 3.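

In this assay, replacing 3,4-dichlorophenyl with 2,4-dimethylphenyl on the ring amine nitrogen now has a real effect, giving a number 15 percentage points lower from compound 3 to compound 4 (beyond the scatter). The outcome of this exchange therefore depends on what the rest of the molecule carries, as the same change reads differently on the two cores: the same change on two cores in this assay, a number 1.6 percentage points higher (within the scatter) from compound 1 to compound 2 and a number 15 percentage points lower (beyond the scatter) from compound 3 to compound 4, 16.6 percentage points apart, beyond the scatter of two such steps The gain linked to 3,4-dimethoxyphenyl in place of phenyl also appears with 2,4-dimethylphenyl on the nitrogen, at a number 33.5 percentage points higher from compound 2 to compound 4 (beyond the scatter), but its size depends on the group at that nitrogen: the same change on two cores in this assay, a number 50.1 percentage points higher (beyond the scatter) from compound 1 to compound 3 and a number 33.5 percentage points higher (beyond the scatter) from compound 2 to compound 4, 16.6 percentage points apart, beyond the scatter of two such steps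

The compounds shown leave open whether the kind of substituent or its place on the ring matters more, as the two groups on the nitrogen differ in both. A 3,4-dimethylphenyl group on that nitrogen, in a compound that keeps the 3,4-dimethoxyphenyl group, would help separate the two.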